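Chain length in a spirocyclic series: compound 1 to compound 4

The compounds below may be only part of what the source reports. "The series", "measured", "known", "first", "only" and "open" are said of these compounds alone.

Measured compounds:
- Compound 1 `CC(C)(C)OC(=O)NCCCCNC(=O)CN1CN(c2ccccc2)C2(CCN(C(=O)c3ccc(C(C)(C)C)cc3)CC2)C1=O` — "not determined" (no result reported)
- Compound 2 `CC(C)(C)c1ccc(C(=O)N2CCC3(CC2)C(=O)N(CC(=O)N2CCN(S(C)(=O)=O)CC2)CN3c2ccccc2)cc1` — 19000 nM
- Compound 3 `CC(C)(C)OC(=O)NC1CCCN(C(=O)CN2CN(c3ccccc3)C3(CCN(C(=O)c4ccc(C(C)(C)C)cc4)CC3)C2=O)C1` — 4200 nM

The three compounds share one core and differ only in the group carried on the amide at the end of the glycine linker. In an assay on HEK293 cells for displacement of a labelled ligand from NPC1-like intracellular cholesterol transporter 1 (Homo sapiens) (on this read-out higher numbers stand for weaker inhibition and lower numbers for stronger inhibition), compound 2 gives 19000 nM, and in this assay compound 3 gives 4200 nM. Compound 1, which carries a carbamate-capped diamine chain, gives "not determined" (no result reported) in this assay, so it cannot be placed among the others; it is neither known to be stronger nor weaker than compound 2 or compound 3.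

Compound 4 `CC(C)(C)OC(=O)NCCCCCNC(=O)CN1CN(c2ccccc2)C2(CCN(C(=O)c3ccc(C(C)(C)C)cc3)CC2)C1=O` differs from compound 1 by one unit of chain length: ((tert-butoxycarbonyl)amino)methyl in place of (tert-butoxycarbonyl)amino on a saturated chain carbon, four bonds along the chain from an amide-type nitrogen. With no measured value for compound 1, the step to compound 4 in this assay cannot be compared to a reference; one chain carbon more or less in such a linker would be expected to change the read-out by no more than the ordinary scatter, if at all.

Resting only on compound 2 and compound 3, which bracket the range seen for this core, compound 4 is expected to give about 8000 nM in this assay, within 2000 nM to 35000 nM.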

Compound 4, half-maximal inhibitory concentration: 13700 nM
Compound 4: middle estimate off by 1.7-fold (0.23 log units), on the low side, within the range that was stated.
By their numbers in this assay, from the lowest: compound 3; then compounds 4 and 2 (each within the scatter of the next).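

In this assay compound 4 gives 13700 nM and compound 1 stands without a number, so no step can be read from compound 1 to compound 4. Going by these compounds, what one more chain carbon does to the read-out stays open. Nothing shown here bears on the value of compound 4.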